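Removing a Trifluoromethyl Group from Compound 2

A few compounds are considered here, and "the series" means these few. Any claim that something is new, unique, unknown or untested is made for them only; others in the source may bear on it.

Values from a functional assay on MDA-MB-435 cells (Homo sapiens) for inhibition, read by sulforhodamine B assay, with a stated time of 48 h (a higher number here means a weaker inhibitor of growth, a lower number a stronger inhibitor of growth), for the measured compounds
- compound 1 `O=C(Nc1cccc(-n2cc(-c3ccncc3)c(-c3ccc(Cl)c(O)c3)n2)c1)Nc1cccc(C(F)(F)F)c1` gives 12600 nM
- compound 2 `COc1cc(-c2nn(-c3cccc(NC(=O)c4cccc(C(F)(F)F)c4)c3)cc2-c2ccncc2)ccc1Cl` gives 1770 nM

Compound 2 holds the lower number of the pair, and its gap to compound 1 lies beyond the scatter. Compound 3 `COc1cc(-c2nn(-c3cccc(NC(=O)c4ccccc4)c3)cc2-c2ccncc2)ccc1Cl` has hydrogen in place of trifluoromethyl on an aromatic carbon relative to compound 2 (hydrogen in place of trifluoromethyl on an aromatic carbon). Among the measured compounds shown here, no measured pair isolates this change, so its size remains a judgement. In this assay the step of a 2.1-fold higher number from compound 2 to compound 3 (0.33 log units; beyond the scatter) is expected to be modest, towards weaker growth inhibition and near the edge of the scatter. The estimate for compound 3 is 3800 nM with an expected range of 1500 nM to 11000 nM in this measure.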

Compound 3, concentration for total growth inhibition: 551 nM
Compound 3: the middle estimate sits 6.9-fold (0.84 log units) above what was measured; measured number outside the range, below it.
By their numbers in this assay, from the lowest: compound 3; then compound 2; then compound 1.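

In this assay, a 3.2-fold lower number from compound 2 to compound 3 (0.51 log units; beyond the scatter) shows that this position tolerates the loss of trifluoromethyl, and that 3-(trifluoromethyl)phenyl gives way to phenyl with a gain in growth inhibition rather than a loss. Among the compounds shown here, this is the first step here that isolates a single place, as compound 1 and compound 2 differ in more than one. Nothing available accounts for the direction of this step.

From the compounds shown here alone, whether an amine or a carboxylic acid at this aromatic carbon would keep that gain remains open. So does whether the same change would act alike on compound 1.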